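Solubility of a trifluoromethyl-substituted benzyl analogue

A few compounds are considered here, and "the series" means these few. Any claim that something is new, unique, unknown or untested is made for them only; others in the source may bear on it.

The series shares one core, varied only at a single aromatic position. Compound 1 `COc1ccc(F)cc1CNCCCNc1ccnc2cc(Oc3ccc(C(C)(C)C)cc3)ccc12` carries a 4-(tert-butyl)phenoxy group there and in a physicochemical assay for solubility, with a stated time of 18 h, at pH 7.4 (a higher number here means a more soluble compound, a lower number a less soluble compound), compound 1 gives 14500 nM. Compound 2 `COc1ccc(F)cc1CNCCCNc1ccnc2cc(Cc3ccc(C#N)cc3)ccc12` has a 4-cyanobenzyl group instead, and in this assay compound 2 gives 4200 nM. Compound 3 `COc1ccc(F)cc1CNCCCNc1ccnc2cc(Cc3ccccc3)ccc12` bears a plain benzyl, and in this assay compound 3 gives 4200 nM.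

Compound 3 thus stands level with compound 2, the two together at the lowest value of the three, while compound 1 sits above both, as shown by a 3.5-fold lower number from compound 1 to compound 3 (0.54 log units; beyond the scatter) and a 3.5-fold lower number from compound 1 to compound 2 (0.54 log units; beyond the scatter). The step of no change at the digits printed from compound 2 to compound 3 (within the scatter) shows that removing the nitrile changed nothing.

Compound 4 `COc1ccc(F)cc1CNCCCNc1ccnc2cc(Cc3cccc(C(F)(F)F)c3)ccc12` differs from compound 3 by trifluoromethyl in place of hydrogen on an aromatic carbon. Among the compounds with values here, no measured step introduces a trifluoromethyl group, so the closest guide is compound 2 against compound 3, where a small aromatic substituent made no difference, and compounds 1 to 3, where a larger group shift gave a modest change. The step of a 1.7-fold lower number from compound 3 to compound 4 (0.23 log units; within the scatter) is therefore expected to be small, if anything a slight lowering. In this assay compound 4 is estimated at 2500 nM, within 800 nM to 8000 nM.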

Compound 4, solubility: 4200 nM
Estimate against measurement, compound 4: 1.7-fold (0.23 log units) below, and the stated range covers the measured number.
By their numbers in this assay, from the lowest: compounds 2, 3 and 4 (each within the scatter of the next); then compound 1.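

In this assay, the step of no change at the digits printed from compound 3 to compound 4 (within the scatter) shows that trifluoromethyl, with its 4 heavy atoms, leaves the number unmoved on this ring, just as the nitrile did in the earlier comparison of compound 2 and compound 3. The step of no change at the digits printed from compound 2 to compound 4 (within the scatter) adds that 3-(trifluoromethyl)phenyl and 4-cyanophenyl cannot be told apart here, while the step of a 3.5-fold lower number from compound 1 to compound 4 (0.54 log units; beyond the scatter) shows that the gap to the 4-(tert-butyl)phenoxy compound persists for a third benzyl compound, so all three benzyl compounds now share one level. No measurement offered here bears on why these benzyl compounds share that level.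

The compounds shown leave open whether this level would hold for a benzyl ring carrying an amine or a carboxylic acid, or for a longer chain in place of the single carbon that links the ring to the shared core. They also leave open how much of the gap to compound 1 belongs to the oxygen link and how much to the tert-butyl group, since a plain phenoxy group and a 4-(tert-butyl)benzyl group do not appear among them.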